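The compounds below may be only part of what the source reports. "The series", "measured", "known", "first", "only" and "open" are said of these compounds alone.

In a functional assay on HeLa cells (Homo sapiens) for antiproliferative activity, read by MTT assay, with a stated time of 72 h (a lower number here means a stronger inhibitor, a higher number a weaker inhibitor), compound 2 (`COc1ncc(-c2ccc3c(c2)N(C2CCCCC2)C(=O)CO3)cc1NS(=O)(=O)c1ccc(F)cc1`) gives 6100 nM and compound 1 (`COc1ncc(-c2ccc3c(c2)N(c2ccc(C)cc2)C(=O)CO3)cc1NS(=O)(=O)c1ccc(F)cc1`) gives 4650 nM, so the two stand within the scatter of each other. Compound 3 (`COc1ncc(-c2ccc3c(c2)N(C2CC2)C(=O)CO3)cc1NS(=O)(=O)c1ccc(F)cc1`) has not yet been measured. It carries cyclopropyl in place of cyclohexyl on an amide-type nitrogen in a ring. Going by the values given here, the only measured step at this nitrogen, a 1.3-fold higher number from compound 1 to compound 2 (0.12 log units; within the scatter), lies within the scatter, so no shift beyond the scatter is expected here. The expected step is a 1.1-fold lower number from compound 2 to compound 3 (0.04 log units; within the scatter). For compound 3 the estimated value in this assay is 5500 nM, with an expected range of 2200 nM to 13000 nM.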

Compound 3, half-maximal inhibitory concentration: 6030 nM
The estimate for compound 3 lay 1.1-fold (0.04 log units) below the measured number, within the range that was stated.
By their numbers in this assay, from the lowest: compounds 1, 3 and 2 (each within the scatter of the next).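

In this assay, replacing the group on the amide-type nitrogen in a ring gives a 1.0-fold lower number from compound 2 to compound 3 (0.01 log units; within the scatter) for cyclopropyl in place of cyclohexyl and a 1.3-fold higher number from compound 1 to compound 3 (0.11 log units; within the scatter) for cyclopropyl in place of 4-methylphenyl. Going from 6 heavy atoms to 3 in this carbon ring therefore leaves the number within the scatter, and cyclopropyl, cyclohexyl and 4-methylphenyl all read alike at this nitrogen. Nothing available accounts for this result. The compounds shown leave open whether an amine or a carboxylic acid carried on this nitrogen would move the number beyond the scatter. They also leave open how changes elsewhere on the shared core would read.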